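The source may report more compounds than this note shows. Statements on the series, on what has been measured and on what is new or still open speak of the compounds shown alone.

Measured so far:
Compound 1, `Cc1ccc(-c2nn(-c3ccc(Cl)cc3)cc2C(CC(=O)c2ccc(Cl)cc2)C(=O)c2ccc(F)cc2)cc1`, gives 25.9% in a functional assay on the whole organism (strain Wistar albino) for inhibition, with Rattus norvegicus as the target, read by paw edema, with stated times of 1 h and 2 h, at a dose of 0.32 mmol/kg by the intraperitoneal route; on this read-out lower numbers stand for less inhibition and higher numbers for more inhibition at the one dose given (going by the name of the read-out).
Compound 2, `COc1ccc(C(=O)C(CC(=O)c2ccc(Cl)cc2)c2cn(-c3ccc(Cl)cc3)nc2-c2ccc(C)cc2)cc1`, gives 16.1% in this assay.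
Compound 3, `COc1ccc(C(=O)C(CC(=O)c2ccc(Cl)cc2)c2cn(-c3ccc(Cl)cc3)nc2-c2ccc(OC)cc2)cc1`, gives 0% in this assay.

Among these three compound 2 stands second highest. Its nearest neighbour is compound 1: the step of a number 9.8 percentage points lower from compound 1 to compound 2 (within the scatter), so the two cannot be told apart. Its furthest is compound 3: the step of a number 16.1 percentage points lower from compound 2 to compound 3 (beyond the scatter).

Compound 4, `COc1ccc(C(=O)C(CC(=O)c2ccc(Cl)cc2)c2cn(-c3ccc(S(N)(=O)=O)cc3)nc2-c2ccc(C)cc2)cc1`, differs from compound 2 in one place: sulfamoyl in place of chloro on an aromatic carbon. Cut one bond further out, the change reads 4-chlorophenyl to 4-sulfamoylphenyl, on an aromatic carbon of a six-membered aromatic ring of carbon only, para to a large group.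

Neither measured step touches this ring or this group; both swap a substituent on another ring for methoxy. Within the data shown here, they show only that one change of a ring substituent moved the read-out downward, once within the scatter and once by a modest amount beyond it. Among the measured compounds shown here, no step therefore gives a size or direction for this assay here. The number for compound 4 in this assay is expected near that of compound 2, at 15%, within 0% to 30%. For compound 4 this estimate means a step of a number 1.1 percentage points lower from compound 2 to compound 4 (within the scatter), expected to stay within the scatter.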

Compound 4, a percentage reported as inhibition, in the whole organism at one dose (the size of the read-out at that dose, not a potency): 53.8%
Compound 4: the middle estimate sits 38.8 percentage points below what was measured; the measured number lies above the stated range.
By their numbers in this assay, from the lowest: compound 3; then compounds 2 and 1 (each within the scatter of the next); then compound 4.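

Changing 4-chlorophenyl to 4-sulfamoylphenyl in this assay gives a number 37.7 percentage points higher from compound 2 to compound 4 (beyond the scatter) and shows that this ring position, untouched by the earlier changes, can shift the read-out strongly and upward. The change replaces a single chlorine with a sulfamoyl group of four heavy atoms that carries one hydrogen-bond donor and two hydrogen-bond acceptors, whereas chloro carries none, but a single step cannot show which of these differences matters. Nothing available here explains the rise.

From the compounds shown here alone, it remains open whether another group at this position, such as a methylsulfonyl group, a carboxylic acid or an amine, would give a similar read-out. Going by these compounds, it is also open whether the same swap would raise the number on the methoxy-bearing partner, compound 3.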